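Solubility of a Cyclopropylmethyl Ether and Its Oxazole Replacement

The source may report more compounds than this note shows. Statements on the series, on what has been measured and on what is new or still open speak of the compounds shown alone.

Compound 1, `Cc1ocnc1COc1cc(Cl)cc(-c2cc(-c3ccccc3C#N)cn(-c3cccnc3)c2=O)c1`: 13.1 ug/mL
Compound 2, `Cn1cc(-c2cc(-c3cc(Cl)cc(OCC4CC4)c3)c(=O)n(-c3cccnc3)c2)c(=O)[nH]c1=O`: 14.2 ug/mL

In a physicochemical assay for solubility, using the shake flask method, with a stated time of 48 h, at pH 6.5 (a lower number here means a less soluble compound, a higher number a more soluble compound), compound 2 gives the higher of the two numbers, yet compound 1 sits within the scatter of it, so the two cannot be told apart. Compound 3, `Cn1cc(-c2cc(-c3cc(Cl)cc(OCc4ocnc4C(F)(F)F)c3)c(=O)n(-c3cccnc3)c2)c(=O)[nH]c1=O`, has not been measured in this assay. It differs from compound 2 in one place: a group of 9 heavy atoms (4 carbon, 1 nitrogen, 1 oxygen, 3 fluorine; one five-membered aromatic ring with 2 hetero atoms) in place of a group of 3 heavy atoms (3 carbon; one three-membered non-aromatic ring of carbon only), on a saturated chain carbon bound to an oxygen on an aromatic ring. Within the data shown here, no measured pair shows this change, so only a modest step is expected, downward, as a 2.0-fold lower number from compound 2 to compound 3 (0.31 log units; beyond the scatter). Compound 3 is therefore estimated at 7 ug/mL, within a range of 2.5 ug/mL to 20 ug/mL.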

Compound 3, solubility: 34.5 ug/mL
The estimate for compound 3 lay 4.9-fold (0.69 log units) below the measured number; the whole stated range lies below it.
By their numbers in this assay, from the lowest: compounds 1 and 2 (each within the scatter of the next); then compound 3.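

At this saturated chain carbon bound to an oxygen on an aromatic ring, putting the group of 9 heavy atoms with its five-membered aromatic ring in place of cyclopropyl gives, in this assay, a 2.4-fold higher number from compound 2 to compound 3 (0.39 log units; beyond the scatter). Among these compounds, this is the first step at this place, and it shows that the read-out can move beyond the scatter with a change here alone. Nothing measured here accounts for the rise. Going by these compounds, whether the step belongs to the ring itself or to its trifluoromethyl stays open. Also open, on these data alone, is how an amine or a carboxylic acid would behave on this carbon.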